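Dihydropyridine amides: ring size of the amide nitrogen

A few compounds are considered here, and "the series" means these few. Any claim that something is new, unique, unknown or untested is made for them only; others in the source may bear on it.

Measured so far:
compound 1 `COC(=O)C1=C(C)NC(C)=C(C(=O)OC)C1c1cccc(OCC(=O)N2CCN(C)CC2)c1` gives 10000 nM in an assay on cells for inhibition of Voltage-gated L-type calcium channel (Rattus norvegicus), read by fluorescence and calcium flux, with stated times of 30 min and 2 min; a higher number here means a weaker inhibitor, a lower number a stronger inhibitor
compound 2 `COC(=O)C1=C(C)NC(C)=C(C(=O)OC)C1c1ccc(OCC(=O)N2CCCCC2)c(OC)c1` gives 10000 nM in this assay
compound 3 `COC(=O)C1=C(C)NC(C)=C(C(=O)OC)C1c1cccc(OCC(=O)N2CCCCC2)c1` gives 10000 nM in this assay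

Compound 2 stands level with compound 1 and compound 3 at the digits shown, within the scatter of each. For the measured compounds named here, the one step between measured compounds that differ in a single place is no change at the digits printed from compound 1 to compound 3 (within the scatter), and it leaves the read-out unchanged. That step swaps one saturated nitrogen ring for another on the same carbonyl carbon, which is the kind of change now proposed.

Compound 4 `COC(=O)C1=C(C)NC(C)=C(C(=O)OC)C1c1ccc(OCC(=O)N2CCCC2)c(OC)c1` differs from compound 2 in one place: pyrrolidin-1-yl in place of piperidin-1-yl on a carbonyl carbon. Going by the values given here, no measured pair shows this particular exchange, so the bearing of the step from compound 1 to compound 3 is indirect. Given that the measured ring swap moved nothing, no step beyond the scatter is expected in this assay for compound 4; the estimate is no change at the digits printed from compound 2 to compound 4 (within the scatter). Compound 4 is therefore expected to give 10000 nM, within a range of 4000 nM to 25000 nM.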

Compound 4, half-maximal inhibitory concentration: 5600 nM
The estimate for compound 4 lay 1.8-fold (0.25 log units) above the measured number, and the stated range covers the measured number.
By their numbers in this assay, from the lowest: compounds 4, 1, 2 and 3 (each within the scatter of the next).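

In this assay, pyrrolidin-1-yl in place of piperidin-1-yl on a carbonyl carbon gives a 1.8-fold lower number from compound 2 to compound 4 (0.25 log units; within the scatter) and so does not separate the five-membered ring from the six-membered ring at this position. Together with the exchange of 4-methylpiperazin-1-yl for piperidin-1-yl (no change at the digits printed from compound 1 to compound 3 (within the scatter)), this makes two ring exchanges on this carbonyl carbon, in two different pairs of compounds, and neither lies beyond the scatter. No measurement on hand offers an explanation of these numbers.

From the compounds shown here alone, whether morpholin-4-yl or an open-chain dimethylamino group on the same carbonyl carbon would stand apart from these compounds remains open. So does the reading of pyrrolidin-1-yl on the core of compound 3, which lacks the methoxy group of compound 2.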